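The source may hold more compounds than are shown below. What is called first, only, known or untested is meant among the compounds shown, and "the series" means these compounds.

Compound 1, with the structure `Cc1ccc(NC(=O)CCCn2cc(-c3ccc(C(F)(F)F)cc3)nn2)cc1`, gives 25000 nM in a functional assay on A549 cells (Homo sapiens) for inhibition, read by MTT assay, with a stated time of 72 h; on this read-out higher numbers stand for weaker inhibition and lower numbers for stronger inhibition. Compound 2, with the structure `O=C(CCCn1cc(-c2ccc(C(F)(F)F)cc2)nn1)Nc1ccc(-c2ccccc2)cc1`, gives 19100 nM in this assay, so that the step of a 1.3-fold lower number from compound 1 to compound 2 (0.12 log units; within the scatter) came with the change (phenyl in place of methyl on an aromatic carbon). Compound 3, with the structure `COC(=O)c1ccc(-c2cn(CCCC(=S)Nc3ccc(C)cc3)nn2)cc1`, gives 50000 nM in this assay; how its core differs from the core of compound 1 is not broken down here. Compound 4, with the structure `COC(=O)c1ccc(-c2cn(CCCC(=S)Nc3ccc(-c4ccccc4)cc3)nn2)cc1`, carries the change (phenyl in place of methyl on an aromatic carbon), the same change that was made from compound 1 to compound 2. Because the earlier step of a 1.3-fold lower number from compound 1 to compound 2 (0.12 log units; within the scatter) stayed within the scatter, the step of a 1.3-fold lower number from compound 3 to compound 4 (0.10 log units; within the scatter) is expected to be of a like size. On that basis compound 4 is estimated at 40000 nM in this assay, with a range from 15000 nM to 100000 nM.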

Compound 4, half-maximal inhibitory concentration: 42300 nM
Beside the measured number, compound 4's estimate is 1.1-fold (0.02 log units) below it, and the stated range covers the measured number.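

In this assay, phenyl in place of methyl on an aromatic carbon gave a 1.2-fold lower number from compound 3 to compound 4 (0.07 log units; within the scatter) and so left the number about as it was on this second core. The change therefore behaved alike on the two cores: the same change on two cores in this assay, a 1.3-fold lower number (0.12 log units; within the scatter) from compound 1 to compound 2 and a 1.2-fold lower number (0.07 log units; within the scatter) from compound 3 to compound 4, 1.1-fold (0.04 log units) apart, within the scatter of two such steps. Going by these compounds alone, both steps lie within the scatter, so this shows only that the change made no clear difference on either core, not that it strengthens inhibition or would behave the same way on any other core.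

The compounds shown leave open whether a group other than phenyl on that aromatic carbon, such as an amine or a carboxylic acid, would shift the number beyond the scatter. They also leave open what a longer chain in place of the present one would do.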